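A few compounds are considered here, and "the series" means these few. Any claim that something is new, unique, unknown or untested is made for them only; others in the source may bear on it.

Compound 1 `Fc1ccc2c(c1)CCC(c1nnc(-c3ccccc3)o1)O2` gives 85900 nM in a functional assay; on this read-out lower numbers stand for stronger inhibition and higher numbers for weaker inhibition. Compound 2 `Fc1ccc2c(c1)CCC(c1nnc(C3CCc4cc(F)ccc4O3)o1)O2` gives 87000 nM in this assay. Compound 3 `Fc1ccc2c(c1)CCC(c1nnc(-c3cc(F)c(F)c(F)c3F)o1)O2` gives 85900 nM in this assay.

All three numbers are very high, which on this read-out means only weak inhibition. Compound 1 stands level with compound 3 at the digits shown, and the two together are the lowest of the three numbers; compound 2 lies furthest from compound 1, but that gap is within the usual scatter, so the three compounds cannot be told apart. The group attached to the shared core varies widely among them without moving the number.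

Compound 4 `Fc1ccc2c(c1)CCC(c1nnc(-c3cnccn3)o1)O2` has not yet been measured. It differs from compound 1 in one place: pyrazin-2-yl in place of phenyl on an aromatic carbon. Since three different groups at this position all gave the same weak result, the change is expected to make no difference beyond the scatter: a 1.0-fold higher number from compound 1 to compound 4 (0.00 log units; within the scatter). For compound 4 the value in this assay is estimated at 86000 nM, in a range from 40000 nM to 200000 nM.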

Compound 4, half-maximal inhibitory concentration: 87000 nM
Estimate against measurement, compound 4: 1.0-fold (0.01 log units) below, within the range that was stated.
By their numbers in this assay, from the lowest: compounds 1, 3, 2 and 4 (each within the scatter of the next).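

In this assay, pyrazin-2-yl in place of phenyl on the aromatic carbon gives a 1.0-fold higher number from compound 1 to compound 4 (0.01 log units; within the scatter) in a comparison that changes only this one place. The entering ring has the same number of heavy atoms as phenyl, but it replaces two ring carbons with nitrogen and brings two hydrogen-bond acceptors, and even so compound 4 remains as weak an inhibitor as compound 1. Nothing available here explains why the number stays flat.

Still open, from the compounds shown here alone, is whether a different kind of group on this carbon, such as an amine, a carboxylic acid or a longer alkyl chain, would bring the number down. Going by these compounds, it is also open whether a change elsewhere on the shared core would move the number in this assay at all.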